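Bromo for Chloro in a Series at the Solubility Limit

The compounds below may be only part of what the source reports. "The series", "measured", "known", "first", "only" and "open" are said of these compounds alone.

The measured compounds and their values in a physicochemical assay for solubility, read by spectrophotometry; a lower number here means a less soluble compound, a higher number a more soluble compound:
compound 1, `O=C(c1ccccc1)c1ccc(NC(=O)c2cc(Br)ccc2O)cc1`, gives < 50000 nM.
compound 2, `O=C(NCCCCl)Oc1ccc(Br)cc1C(=O)Nc1ccc(C(F)(F)F)cc1`, gives < 50000 nM.
compound 3, `O=C(NCCCCl)Oc1ccc(Cl)cc1C(=O)Nc1ccc(C(=O)c2ccccc2)cc1`, gives < 50000 nM.

Each of these three readings is a limit of this assay rather than a number. The value given for compound 1 is such a limit. The value given for compound 2 is such a limit. The value given for compound 3 is such a limit as well, so compound 3 stands at the same point as the other two, and no compound can be placed above or below another on the figures shown; the limit of < 50000 nM in this assay, at which 3 of the 3 values shown sit, sums up the whole picture.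

Compound 4, `O=C(NCCCCl)Oc1ccc(Br)cc1C(=O)Nc1ccc(C(=O)c2ccccc2)cc1`, has not yet been measured. It differs from compound 3 by bromo in place of chloro on an aromatic carbon. Among the compounds with values here, no pair of measured compounds here differs in exactly this way, so there is no measured step to lean on. With all three known values sitting at the limit, the expectation for compound 4 in this assay is a step that the limit leaves unreadable from compound 3 to compound 4, that is, no change beyond the scatter in either direction. Compound 4 is therefore expected to give about 20000 nM, within 5000 nM to 50000 nM, most probably reported again only as a limit.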

Compound 4, solubility: < 50000 nM
Compound 4 ended at the assay's limit; the forecaster's own chance of this, stated with the estimate: 85%; the middle value is on the limit's open side.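

In this assay compound 4 gives < 50000 nM, which is a limit of the assay and not a number. Within the data shown here, no step from compound 1, compound 2 or compound 3 to compound 4 can be read, and the picture stays as it was: the limit of < 50000 nM in this assay, at which 4 of the 4 values shown sit. The compounds shown leave open how the four compare, including whether bromo and chloro differ at all.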